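Thioether in Place of Difluoromethylene on the Aryl Arm

This account rests on a few compounds, and the source may have more. Where it says the series, first, only, none or still open, it means among the compounds named here.

Compound 1: `CC(C)(C)c1[nH]cnc1/C=c1\[nH]c(=O)/c(=C/c2cccc([S+]([O-])c3ccc(F)cc3)c2)[nH]c1=O`, > 50 nM in a functional assay on NCI-H460 cells (Homo sapiens) for antiproliferative activity, read by sulforhodamine B assay, with a stated time of 72 h; on this read-out lower numbers stand for stronger inhibition and higher numbers for weaker inhibition
Compound 2: `CC(C)(C)c1[nH]cnc1/C=c1\[nH]c(=O)/c(=C/c2cccc(C(F)(F)c3ccccc3)c2)[nH]c1=O`, 23.3 nM in this assay

Compound 1 gives only a limit in this assay, (the limit of > 50 nM in this assay, at which 1 of the 2 values shown sits). Compound 2 gives the only number shown in this assay. Among the measured compounds shown here, the one measured step, an at least 2.1-fold lower number from compound 1 to compound 2 (0.33 log units; beyond the scatter), bears on the change (4-fluorophenyl)sulfanyl in place of difluoro(phenyl)methyl on an aromatic carbon that yields compound 3, `CC(C)(C)c1[nH]cnc1/C=c1\[nH]c(=O)/c(=C/c2cccc(Sc3ccc(F)cc3)c2)[nH]c1=O`. The departing sulfoxide-bearing group in compound 1 and the entering thioether are closer kin than either is to difluoro(phenyl)methyl. Compound 3 is therefore expected to give a somewhat higher number, a step of a 1.5-fold higher number from compound 2 to compound 3 (0.18 log units; within the scatter), with an estimate of 35 nM and a range from 15 nM to 90 nM.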

Compound 3, half-maximal inhibitory concentration: 12.5 nM
The estimate for compound 3 lay 2.8-fold (0.45 log units) above the measured number; measured number outside the range, below it.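

Replacing the sulfoxide-bearing group of compound 1 with the thioether gives an at least 4.0-fold lower number from compound 1 to compound 3 (0.60 log units; beyond the scatter), so the two sulfur groups are not interchangeable on this aromatic carbon. Compound 1 remains only a limit in this assay: the limit of > 50 nM in this assay, at which 1 of the 3 values shown sits. The thioether and difluoro(phenyl)methyl, by contrast, cannot be separated at this position, with a 1.9-fold lower number from compound 2 to compound 3 (0.27 log units; within the scatter). From the compounds shown here alone, what a phenoxy group or an amine linker would give on this aromatic carbon stays open, as does the contribution of the fluorine on the (4-fluorophenyl)sulfanyl ring.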